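Benzyl aryl substitution and cytotoxicity: compound 3 to compound 4

This account rests on a few compounds, and the source may have more. Where it says the series, first, only, none or still open, it means among the compounds named here.

Three compounds share one core and differ only in the benzyl group carried on the sulfur. Compound 1 `Cc1cccc(CSc2cc(Cl)c(C)cc2S(=O)(=O)/N=C(\N)n2nccc2-c2ccccc2)c1` gives 6500 nM in a functional assay on HCT-116 cells (Homo sapiens) for cytotoxicity, read by MTT assay, with a stated time of 72 h; a lower number here means a stronger inhibitor, a higher number a weaker inhibitor. Compound 2 `Cc1cc(S(=O)(=O)/N=C(\N)n2nccc2-c2ccccc2)c(SCc2cccc(Cl)c2)cc1Cl` gives 7000 nM in this assay. Compound 3 `Cc1cc(S(=O)(=O)/N=C(\N)n2nccc2-c2ccccc2)c(SCc2ccccc2C)cc1Cl` gives 16000 nM in this assay, the highest of the three numbers: a 2.5-fold higher number from compound 1 to compound 3 (0.39 log units; beyond the scatter) and a 2.3-fold higher number from compound 2 to compound 3 (0.36 log units; beyond the scatter), both modest and beyond the scatter, whereas a 1.1-fold higher number from compound 1 to compound 2 (0.03 log units; within the scatter) sits within it.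

Compound 4 `Cc1cc(S(=O)(=O)/N=C(\N)n2nccc2-c2ccccc2)c(SCc2cccc(C(F)(F)F)c2)cc1Cl` has not yet been measured. The change from compound 3 is 3-(trifluoromethyl)phenyl in place of 2-methylphenyl on a saturated chain carbon bound to a sulfur; cut one bond further out it reads 2-methylbenzyl to 3-(trifluoromethyl)benzyl.

Among the measured compounds shown here, two measured steps bear on this move. The steps into compound 3 each replaced a 3-substituted phenyl with 2-methylphenyl and both raised the number modestly; the step from compound 1 to compound 2 exchanged methyl for chloro on the aromatic carbon and stayed within the scatter. Compound 4 returns to a 3-substituted phenyl, so the expectation is that the modest rise is reversed, with the caveat that trifluoromethyl is a substituent not yet seen in the series. The expected step is a 2.3-fold lower number from compound 3 to compound 4 (0.36 log units; beyond the scatter), toward a lower number. For compound 4 the estimate in this assay is 7000 nM, with a range of 3500 nM to 14000 nM.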

Compound 4, half-maximal inhibitory concentration: 14000 nM
Estimate against measurement, compound 4: 2.0-fold (0.30 log units) below, within the range that was stated.
By their numbers in this assay, from the lowest: compounds 1, 2, 4 and 3 (each within the scatter of the next, the first and the last beyond it).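

In this assay, the exchange of 2-methylphenyl for 3-(trifluoromethyl)phenyl on the saturated chain carbon bound to a sulfur gives no separation (a 1.1-fold lower number from compound 3 to compound 4 (0.06 log units; within the scatter)), so a substituent at the 3-position of this phenyl does not in itself go with the lower numbers of compound 1 and compound 2. The identity of that substituent can count here, as trifluoromethyl in place of methyl gives a modest step (a 2.2-fold higher number from compound 1 to compound 4 (0.33 log units; beyond the scatter)), but this reading holds for one pair only, as trifluoromethyl in place of chloro stays within the scatter (a 2.0-fold higher number from compound 2 to compound 4 (0.30 log units; within the scatter)). The earlier link between 3-substituted phenyl groups and lower numbers therefore rested on methyl and chloro alone, with compound 4 going against it when set beside compound 1, and no measured evidence speaks to a cause for these values.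

The compounds shown leave open how an unsubstituted phenyl would stand against these groups, and so whether any substituent on this ring helps at all. They also leave open whether an amine or a carboxylic acid on this phenyl would move the number beyond the narrow span seen so far.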